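Compound 2: from iodo to methoxy

The source may report more compounds than this note shows. Statements on the series, on what has been measured and on what is new or still open speak of the compounds shown alone.

Compound 1 `NC(=O)c1ccccc1NC(=O)COc1ccccc1`: 8900 nM
Compound 2 `NC(=O)c1cc(I)ccc1NC(=O)COc1ccccc1`: 160 nM
Compound 3 `Cc1ccc(OCC(=O)Nc2ccc(I)cc2C(N)=O)cc1`: 10000 nM

In a functional assay on K562 cells (Homo sapiens) for inhibition, read by trypan blue exclusion, with a stated time of 24 h (a lower number here means a stronger inhibitor, a higher number a weaker inhibitor), compound 2 has the lowest number of the three, and its steps to both others lie beyond the scatter. Compound 4 `COc1ccc(NC(=O)COc2ccccc2)c(C(N)=O)c1` is still unmeasured and carries methoxy in place of iodo on an aromatic carbon. The closest evidence is a 56-fold lower number from compound 1 to compound 2 (1.75 log units; beyond the scatter), a large step for iodo in place of hydrogen. The other large step, a 63-fold higher number from compound 2 to compound 3 (1.80 log units; beyond the scatter), is a methyl change elsewhere and bears only indirectly. Among the compounds with values here, no measured compound carries methoxy, so the loss of iodo is expected to cost much of that gain. The expected change is a 19-fold higher number from compound 2 to compound 4 (1.27 log units; beyond the scatter), a large step to a higher number. For compound 4 the estimated value is 3000 nM, with an expected range of 600 nM to 12000 nM.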

Compound 4, half-maximal inhibitory concentration: 1100 nM
Compound 4: the middle estimate sits 2.7-fold (0.44 log units) above what was measured; low and high end bracket the measured number.
By their numbers in this assay, from the lowest: compound 2; then compound 4; then compounds 1 and 3 (each within the scatter of the next).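

Within the data shown here, on this position, para to a large group, iodo is not the only group that lowers the number relative to hydrogen: in this assay methoxy also does so, with an 8.1-fold lower number from compound 1 to compound 4 (0.91 log units; beyond the scatter) in the shared core. Methoxy does not match iodo, however, as a 6.9-fold higher number from compound 2 to compound 4 (0.84 log units; beyond the scatter) shows, so the result at this position depends on which group enters and not only on hydrogen being replaced. Nothing measured here explains this order of the three groups.

From the compounds shown here alone, it remains open where bromo, an amine or a carboxylic acid would fall at this position. Going by these compounds, a longer chain such as ethoxy is equally open, so whether methoxy's gain extends beyond that group cannot be told.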